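Methylphenyl for Trifluoromethylphenyl on the Amide Carbonyl

The source may report more compounds than this note shows. Statements on the series, on what has been measured and on what is new or still open speak of the compounds shown alone.

Measured compounds:
compound 1 `O=C(Nc1cc(-c2ccccc2)nn1-c1ccccc1)c1ccccc1` — 203 nM
compound 2 `O=C(Nc1cc(-c2ccccc2)nn1-c1ccccc1)c1cccc(C(F)(F)F)c1` — 228 nM

Of the compounds shown here, two have been tested in a functional assay on cells for positive allosteric modulation of metabotropic glutamate receptor 5 (Rattus norvegicus), read by calcium flux; on this read-out higher numbers stand for an effect only at larger amounts of compound and lower numbers for an effect already at smaller amounts. Compound 1 gives 203 nM and compound 2 gives 228 nM. Going by the values given here, the one measured step, a 1.1-fold higher number from compound 1 to compound 2 (0.05 log units; within the scatter), shows that adding trifluoromethyl to an aromatic carbon of the shared core left the read-out essentially where it was. Compound 2 therefore holds the higher of the two numbers, but its separation from compound 1 lies within the scatter, so no order can be drawn between them.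

Compound 3 `Cc1ccc(C(=O)Nc2cc(-c3ccccc3)nn2-c2ccccc2)cc1` differs from compound 2 in a single place: 4-methylphenyl in place of 3-(trifluoromethyl)phenyl on a carbonyl carbon. The change concerns the same aryl group that was altered in the step from compound 1 to compound 2, and that step was within the scatter. Among the compounds with values here, no measured pair shows a 4-methylphenyl on the carbonyl carbon, so the expectation rests on that one step alone. Because a 1.1-fold higher number from compound 1 to compound 2 (0.05 log units; within the scatter) was flat, the estimated step of a 1.1-fold lower number from compound 2 to compound 3 (0.04 log units; within the scatter) is expected to stay within the scatter. Compound 3 is accordingly expected to give about 210 nM, with a range from 90 nM to 500 nM.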

Compound 3, half-maximal effective concentration: 64 nM
Compound 3: middle estimate off by 3.3-fold (0.52 log units), on the high side; measured number outside the range, below it.
By their numbers in this assay, from the lowest: compound 3; then compounds 1 and 2 (each within the scatter of the next).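

The aryl group on the carbonyl carbon proved able to move the read-out in this assay: 4-methylphenyl in place of 3-(trifluoromethyl)phenyl gave a 3.6-fold lower number from compound 2 to compound 3 (0.55 log units; beyond the scatter), and methyl in place of hydrogen on an aromatic carbon gave a 3.2-fold lower number from compound 1 to compound 3 (0.50 log units; beyond the scatter). The earlier step, a 1.1-fold higher number from compound 1 to compound 2 (0.05 log units; within the scatter), had suggested that changes to this aryl group might leave the read-out where it was, but compound 3 shows that this does not hold for every change here, since it reaches an effect at smaller amounts than either compound 1 or compound 2. No evidence is available to explain the difference between the methyl and trifluoromethyl compounds.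

Compound 2 and compound 3 differ both in the group carried and in its place on the ring, as the names 3-(trifluoromethyl)phenyl and 4-methylphenyl show, so the compounds shown cannot separate the contribution of the group from that of its place. They also leave open whether an ethyl, a methoxy or a chlorine in the place of the methyl of compound 3 would keep the lower number.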